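The source may report more compounds than this note shows. Statements on the series, on what has been measured and on what is new or still open speak of the compounds shown alone.

Measured so far in a functional assay on MCF7 cells (Homo sapiens) for inhibition, read by resazurin assay, with a stated time of 72 h; a higher number here means a weaker inhibitor, a lower number a stronger inhibitor:
compound 1 `COc1cc(N2C(=O)CC2c2ccc(SC)cc2)cc(OC)c1OC`: 67 nM
compound 2 `CCSc1ccc(C2CC(=O)N2c2cc(OC)c(OC)c(OC)c2)cc1`: 141 nM
compound 3 `COc1ccc(C2C(C3CC3)C(=O)N2c2cc(OC)c(OC)c(OC)c2)cc1`: 120 nM

Compound 1 sits at the low end of this small set. Compound 3 lies within the scatter of it, and only compound 2 stands clearly apart. Compound 4 `COc1cc(N2C(=O)C(Oc3ccccc3)C2c2ccc(SC)cc2)cc(OC)c1OC` keeps the core of compound 1 and makes one change: phenoxy in place of hydrogen on a saturated ring carbon. Phenoxy thus replaces hydrogen on a saturated ring carbon. For the measured compounds named here, the only measured step is a 2.1-fold higher number from compound 1 to compound 2 (0.32 log units; beyond the scatter), a modest one beyond the scatter. It concerns the chain on sulfur rather than this ring carbon, so it offers only a rough scale. Going by the values given here, compound 3, which also carries a group on a saturated ring carbon, gives 120 nM, but it differs from compound 1 elsewhere too, and no measured compound carries phenoxy. A modest step towards a higher number is therefore expected in this assay, with wide uncertainty. The expected step is a 2.2-fold higher number from compound 1 to compound 4 (0.35 log units; beyond the scatter). For compound 4 the estimated value is 150 nM, with an expected range of 40 nM to 600 nM.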

Compound 4, half-maximal inhibitory concentration: 152 nM
Estimate against measurement, compound 4: 1.0-fold (0.01 log units) below, within the range that was stated.
By their numbers in this assay, from the lowest: compounds 1, 3, 2 and 4 (each within the scatter of the next, the first and the last beyond it).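

In this assay, the saturated ring carbon two ring bonds from the ring nitrogen now has its first direct reading: phenoxy in place of hydrogen gives a 2.3-fold higher number from compound 1 to compound 4 (0.36 log units; beyond the scatter). The position therefore accepts a group of seven heavy atoms with a six-membered aromatic ring at only a modest cost, and compound 4 remains at 152 nM. The data offer no measured basis for explaining this step.

The compounds shown leave open whether the step is specific to phenoxy or would follow from other groups on this carbon, such as a hydroxyl, a methoxy or an amine. As far as these compounds go, it is also open how a substituent on the phenoxy ring, such as fluorine or a carboxylic acid, would change the number.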